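The source may hold more compounds than are shown below. What is called first, only, known or untested is meant among the compounds shown, and "the series" means these compounds.

Among the compounds with values here, compound 2 `CN(C)C/C=C/C(=O)Nc1cccc(Nc2nc(N/N=C/c3ccncc3)ncc2Cl)c1` gives 25200 nM in an ADME assay on HT-29 cells (Homo sapiens) for inhibition, read by MTT assay, with a stated time of 72 h (a higher number here means a weaker inhibitor, a lower number a stronger inhibitor), the higher of the two numbers measured so far. Compound 1 `C=CC(=O)Nc1cccc(Nc2nc(N/N=C(\C)c3ccc(C)cc3)ncc2Cl)c1` gives 3210 nM in this assay, and the gap between compound 1 and compound 2 is beyond the scatter. Compound 3 `C/C(=N\Nc1ncc(Cl)c(Nc2cccc(NC(=O)/C=C/CN(C)C)c2)n1)c1ccc(C)cc1` differs from compound 2 by a group of 10 heavy atoms (9 carbon, 1 nitrogen; one six-membered aromatic ring of carbon only) in place of a group of 8 heavy atoms (6 carbon, 2 nitrogen; one six-membered aromatic ring with 1 hetero atom), on a nitrogen on an aromatic ring. Within the data shown here, the entering group is the one found in compound 1, while the rest of compound 2 is kept. A step toward lower numbers is expected, a 5.6-fold lower number from compound 2 to compound 3 (0.75 log units; beyond the scatter), because compound 1 gives 3210 nM with that same group. Compound 3 is expected to give 4500 nM in this assay, within 1500 nM to 13000 nM.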

Compound 3, half-maximal inhibitory concentration: 11800 nM
The estimate for compound 3 lay 2.6-fold (0.42 log units) below the measured number, and the stated range covers the measured number.
By their numbers in this assay, from the lowest: compound 1; then compound 3; then compound 2.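

In this assay the group from compound 1, placed on a nitrogen on an aromatic ring, gives a 2.1-fold lower number from compound 2 to compound 3 (0.33 log units; beyond the scatter) with the rest of compound 2 kept. Within the data shown here, on a carbonyl carbon, 3-(dimethylamino)prop-1-en-1-yl in place of vinyl gives a 3.7-fold higher number from compound 1 to compound 3 (0.57 log units; beyond the scatter) and isolates this change for the first time. No measurement available here accounts for either step.

Open, on these data alone, is how a morpholine or pyrrolidine in place of the dimethylamino group would read. Also open, as far as these compounds go, is how an unsubstituted phenyl group would read on the nitrogen.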